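The compounds below may be only part of what the source reports. "The series", "measured", "known", "first", "only" and "open" are said of these compounds alone.

Three compounds built on the shared core of compound 1 `O=C(c1cc(Cc2n[nH]c(=O)c3ccccc23)ccc1F)N1CCc2nc(Cl)ncc2C1` are followed here, together with a fourth that has not yet been tested. For compound 1 no result is recorded in a functional assay on MDA-MB-231 cells (Homo sapiens) for inhibition, read by MTT assay, with a stated time of 48 h (on this read-out higher numbers stand for weaker inhibition and lower numbers for stronger inhibition), where the entry reads "nd" (no result reported). Compound 2 `CN1CCN(c2ncc3c(n2)CCN(C(=O)c2cc(Cc4n[nH]c(=O)c5ccccc45)ccc2F)C3)CC1` carries a 4-methylpiperazin-1-yl group on the aromatic carbon of its core. In this assay compound 2 gives > 200000 nM, which is a limit of the assay and not a number. Compound 3 `O=C(c1cc(Cc2n[nH]c(=O)c3ccccc23)ccc1F)N1CCc2nc(N3CCCC3)ncc2C1` carries pyrrolidin-1-yl at the same place. In this assay compound 3 gives > 200000 nM, again a limit of the assay. Among the measured compounds shown here, the one measured step, a step that the two limits leave unreadable from compound 2 to compound 3, therefore has no readable size. Compound 4 `CCCCN(CCCC)c1ncc2c(n1)CCN(C(=O)c1cc(Cc3n[nH]c(=O)c4ccccc34)ccc1F)C2` differs from compound 2 as follows: dibutylamino in place of 4-methylpiperazin-1-yl on an aromatic carbon. For the measured compounds named here, no measured step bears on this change in a readable way. Because (the limit of > 200000 nM in this assay, at which 2 of the 3 values shown sit), compound 4 is expected to sit near the same limit, and in this assay compound 4 is estimated at 200000 nM (range 50000 nM to 600000 nM). The expected step of a number no higher from compound 2 to compound 4 (the limit leaves the size open) is thus none beyond the scatter.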

Compound 4, half-maximal inhibitory concentration: > 200000 nM
Compound 4: no number, only a limit; the forecaster's own chance of this, stated with the estimate: 80%; the middle value lies on the limit itself.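

In this assay compound 4 gives > 200000 nM, which is a limit of the assay and not a number. Its steps from compound 2 and compound 3 cannot be read. The compounds shown leave open whether 4-methylpiperazin-1-yl, pyrrolidin-1-yl and dibutylamino differ at all in this assay.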